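Ring-nitrogen swap: aryl out, sulfonyl in, compound 4

A few compounds are considered here, and "the series" means these few. Any claim that something is new, unique, unknown or untested is made for them only; others in the source may bear on it.

Compound 3 `O=C(/C=C/c1ccccc1)c1ccc(N2CCN(c3ccccc3Cl)CC2)cc1` gives 4.71% in a functional assay on the whole organism (strain Kunming) for inhibition, with Mus musculus as the target, with a stated time of 1 h, at a dose of 40 mg/kg by the oral route (on this read-out higher numbers stand for more inhibition at the one dose given (going by the name of the read-out) and lower numbers for less inhibition), the smallest of the three numbers shown. Compound 2 `O=C(/C=C/c1ccccc1)c1ccc(N2CCN(c3cccc(Cl)c3)CC2)cc1` gives 14.1%, and a number 9.4 percentage points lower from compound 2 to compound 3 (within the scatter) stays within the scatter. Compound 1 `Cc1ccc(N2CCN(c3ccc(C(=O)/C=C/c4ccccc4)cc3)CC2)c(C)c1` gives 15%, and a number 10.3 percentage points lower from compound 1 to compound 3 (beyond the scatter) is the only gap beyond it. The change to compound 4 `Cc1ccc(S(=O)(=O)N2CCN(c3ccc(C(=O)/C=C/c4ccccc4)cc3)CC2)cc1` is (4-methylphenyl)sulfonyl in place of 2-chlorophenyl on an amine nitrogen in a ring. The measured steps exchange one aryl group for another on that nitrogen, a number 0.9 percentage points lower from compound 1 to compound 2 (within the scatter) and a number 10.3 percentage points lower from compound 1 to compound 3 (beyond the scatter), and none exchanges an aryl group for a sulfonyl group, so they bear only loosely on this step; all of them moved this assay little. The step expected is a number 7.3 percentage points higher from compound 3 to compound 4 (within the scatter), with no direction beyond the scatter. Compound 4 is estimated at 12% in this assay. The expected range for compound 4 runs from 2% to 25%.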

Compound 4, a percentage reported as inhibition, in the whole organism at one dose (the size of the read-out at that dose, not a potency): 30.8%
For compound 4 the middle estimate is 18.8 percentage points below the measured one; measured number above the stated range.
By their numbers in this assay, from the lowest: compounds 3, 2 and 1 (each within the scatter of the next, the first and the last beyond it); then compound 4.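

In this assay, for the compounds shown here, the one sulfonyl compound stands clear of all three aryl compounds (a number 26.1 percentage points higher from compound 3 to compound 4 (beyond the scatter); a number 16.7 percentage points higher from compound 2 to compound 4 (beyond the scatter); a number 15.8 percentage points higher from compound 1 to compound 4 (beyond the scatter)). The aryl exchanges on this amine nitrogen gave a single modest gap at most, so the series now shows that replacing the aryl group with (4-methylphenyl)sulfonyl can shift this read-out more than those exchanges did. Nothing available accounts for the rise.

Going by these compounds, whether the gain follows the sulfonyl link or the 4-methylphenyl on it remains open. A methylsulfonyl or a benzoyl group on the same nitrogen would separate the two.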